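From 2-chlorobenzyl to 4-(tert-butyl)benzyl in compound 3

The source may report more compounds than this note shows. Statements on the series, on what has been measured and on what is new or still open speak of the compounds shown alone.

Compounds measured so far in a functional assay on A549 cells (Homo sapiens) for cytotoxicity, read by MTT assay, with a stated time of 72 h; on this read-out lower numbers stand for stronger inhibition and higher numbers for weaker inhibition

- compound 1 `CCN(CC)Cc1ccc2nc(NC(=O)N/N=C/c3cn(Cc4ccc(C(C)(C)C)cc4)c4ccccc34)sc2c1` gives 1710 nM
- compound 2 `Cc1ccc(Cn2cc(/C=N/NC(=O)Nc3nc4ccc(CN5CCC(C)CC5)cc4s3)c3ccccc32)cc1` gives 2180 nM
- compound 3 `CC1CCN(Cc2ccc3nc(NC(=O)N/N=C/c4cn(Cc5ccccc5Cl)c5ccccc45)sc3c2)CC1` gives 3330 nM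

In this assay compound 3 gives 3330 nM, a value within the scatter of those of compound 2 and compound 1. These three numbers therefore set no firm order among the compounds.

The next compound, compound 4 `CC1CCN(Cc2ccc3nc(NC(=O)N/N=C/c4cn(Cc5ccc(C(C)(C)C)cc5)c5ccccc45)sc3c2)CC1`, keeps the rest of compound 3 and changes one group (4-(tert-butyl)phenyl in place of 2-chlorophenyl on a saturated chain carbon bound to an aromatic nitrogen), with 4-(tert-butyl)phenyl in place of 2-chlorophenyl on a saturated chain carbon bound to an aromatic nitrogen.

For the measured compounds named here, one measured step concerns this same place, a 1.5-fold higher number from compound 2 to compound 3 (0.18 log units; within the scatter), where 2-chlorophenyl replaces 4-methylphenyl, and it stays within the scatter. Compound 1 already carries 4-(tert-butyl)phenyl at this place and gives 1710 nM, but it also differs from compound 4 elsewhere, so it offers only indirect support. Going by the values given here, no measured step isolates the new group.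

The data therefore give no reason to expect a change beyond the scatter. The expected step is a 1.4-fold lower number from compound 3 to compound 4 (0.16 log units; within the scatter), small and toward a lower number. For compound 4 the estimated value is 2300 nM, with an expected range of 1100 nM to 4600 nM.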

Compound 4, half-maximal inhibitory concentration: 3710 nM
Beside the measured number, compound 4's estimate is 1.6-fold (0.21 log units) below it; the range from low to high includes it.
By their numbers in this assay, from the lowest: compounds 1, 2, 3 and 4 (each within the scatter of the next, the first and the last beyond it).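

In this assay, the change from 2-chlorophenyl to 4-(tert-butyl)phenyl on a saturated chain carbon bound to an aromatic nitrogen can now be read directly: a 1.1-fold higher number from compound 3 to compound 4 (0.05 log units; within the scatter). A second direct reading at this place comes from tert-butyl in place of methyl on an aromatic carbon, a 1.7-fold higher number from compound 2 to compound 4 (0.23 log units; within the scatter), so with 4-methylpiperidin-1-yl held constant, none of these three groups is set apart from the others. For the compounds shown here, the only step beyond the scatter lies at the other place, where 4-methylpiperidin-1-yl stands in place of diethylamino on a saturated chain carbon bound to an aromatic carbon, a 2.2-fold higher number from compound 1 to compound 4 (0.34 log units; beyond the scatter), and this modest step is the first sign that the amine can matter in this set.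

No measurement shown explains any of these steps. The compounds shown leave open whether the difference between diethylamino and 4-methylpiperidin-1-yl also appears with 2-chlorophenyl or 4-methylphenyl at the first place, and whether a morpholine at the amine place or a carboxylic acid on the phenyl ring would move the number beyond the scatter.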